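This account rests on a few compounds, and the source may have more. Where it says the series, first, only, none or still open, it means among the compounds named here.

Measured in a functional assay on A549 cells (Homo sapiens) for inhibition (on this read-out lower numbers stand for stronger inhibition and higher numbers for weaker inhibition), so far:
Compound 1 `Oc1ccc(/C=C/c2ccc3ccccc3c2)cc1` gives 4060 nM
Compound 2 `FC(F)(F)Oc1ccc(/C=C/c2ccc3ccccc3c2)cc1` gives > 5000 nM as a limit

Compound 2 has no number on this read-out, only the limit > 5000 nM of the assay. That is the limit of > 5000 nM in this assay, at which 1 of the 2 values shown sits, and the only place it can be put.

Compound 3 `CN(C)c1ccc(/C=C/c2ccc3ccccc3c2)cc1` carries dimethylamino in place of trifluoromethoxy on an aromatic carbon and shares the rest of its structure with compound 2.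

Just one measured step bears on this position, namely an at least 1.2-fold higher number from compound 1 to compound 2 (0.09 log units; that floor lies within the scatter) for trifluoromethyl in place of hydrogen on an oxygen on an aromatic ring. It gives no sign of a large swing, so only a modest move towards a lower number is expected in this assay here. The expected size is an at least 1.6-fold lower number from compound 2 to compound 3 (0.22 log units; that floor lies within the scatter) in this estimate.

For compound 3 the estimated value is 3000 nM with an expected range from 800 nM to 9000 nM in this assay.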

Compound 3, half-maximal inhibitory concentration: 3660 nM
The estimate for compound 3 lay 1.2-fold (0.09 log units) below the measured number; the measured number falls inside the stated range.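

In this assay, dimethylamino on this aromatic carbon gives a measured number, and its exchange for hydroxy reads as a 1.1-fold lower number from compound 1 to compound 3 (0.05 log units; within the scatter), so on this read-out the two groups cannot be told apart at this position. The exchange for trifluoromethoxy reads as an at least 1.3-fold lower number from compound 2 to compound 3 (0.13 log units; that floor lies within the scatter), which is a floor only and does not show a change beyond the scatter. Compound 2 holds a limit rather than a number: the limit of > 5000 nM in this assay, at which 1 of the 3 values shown sits.

The compounds shown leave open how far compound 2 truly lies from the other two. They also leave open whether a carboxylic acid, a primary amine or a longer alkoxy chain on this aromatic carbon would move the number beyond the scatter.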